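Benzoyl on the amide nitrogen of compound 3

The compounds below may be only part of what the source reports. "The series", "measured", "known", "first", "only" and "open" are said of these compounds alone.

Compound 3 `COc1ccc(-c2nc(NC(=O)c3ccccc3)n(-c3ccccc3)n2)cc1` carries a benzamido group and gives 50% in an assay on CHO cells for displacement of a labelled ligand from adenosine receptor A3 (Homo sapiens), tested at 1 uM; on this read-out lower numbers stand for less inhibition and higher numbers for more inhibition at the one concentration tested (going by the name of the read-out). That is the highest of the three numbers measured: compound 1 `CCOC(=O)Nc1ccc(C)cc1-n1cnc(-c2ccc(OC)cc2)n1` gives 34%, and compound 2 `COc1ccc(-c2nc(N(C(C)=O)C(C)=O)n(-c3ccccc3)n2)cc1` gives 19%; both gaps to compound 3 lie beyond the scatter.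

Compound 4 `COc1ccc(-c2nc(N(C(=O)c3ccccc3)C(=O)c3ccccc3)n(-c3ccccc3)n2)cc1` is not yet measured. It differs from compound 3 by benzoyl in place of hydrogen on an amide-type nitrogen, so compound 4 is the doubly acylated counterpart of compound 3.

For the measured compounds named here, one measured step bears on this. The step of a number 31 percentage points higher from compound 2 to compound 3 (beyond the scatter) sets a nitrogen bearing two acetyl groups against one bearing a single benzoyl and a hydrogen; it changes the kind and the number of acyl groups at once and does not separate the two. Compound 4 keeps the benzoyl of compound 3 but takes on the doubly acylated pattern of compound 2, the only such nitrogen measured, which stands with 19% at the bottom of the set. On that ground a downward step is expected, kept smaller than the measured one since the benzoyl is retained.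

The step expected in this assay is a number 20 percentage points lower from compound 3 to compound 4 (beyond the scatter). Compound 4 is estimated at 30%, with a range from 12% to 48%.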

Compound 4, a percentage reported as inhibition, at one concentration (the size of the read-out at that concentration, not a potency): 44%
Compound 4: the middle estimate sits 14 percentage points below what was measured; measured number inside the range.
By their numbers in this assay, from the lowest: compound 2; then compounds 1, 4 and 3 (each within the scatter of the next, the first and the last beyond it).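

Adding benzoyl in place of hydrogen on the amide-type nitrogen gives a number 6 percentage points lower from compound 3 to compound 4 (within the scatter) in this assay, so in this pair neither the loss of the amide hydrogen nor a second acyl group moves the read-out past the usual scatter. A doubly acylated nitrogen is therefore not tied to a low number in this series. The large step of a number 31 percentage points higher from compound 2 to compound 3 (beyond the scatter) changes both the kind and the number of acyl groups. The kind of acyl group remains an open candidate for that step. No measurement at hand accounts for this result.

The compounds shown leave open how a single acetyl with the amide hydrogen kept would read on this nitrogen, a comparison that would separate the kind of acyl group from the number, and how a plain amine would read with both acyl positions empty. Also open, going by these compounds, is whether a longer chain such as hexanoyl would read like acetyl or like benzoyl, and how any of these would compare as potencies, since the read-out covers one concentration only.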